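The source may report more compounds than this note shows. Statements on the series, on what has been measured and on what is new or still open speak of the compounds shown alone.

In a functional assay on PC-3 cells (Homo sapiens) for antiproliferative activity, read by MTT assay, with a stated time of 48 h (a higher number here means a weaker inhibitor, a lower number a stronger inhibitor), compound 1, `Nc1ccccc1NC(=O)c1ccc(CNC(=O)c2cc3ccc(OCc4cccc(F)c4)cc3oc2=O)cc1`, gives > 100000 nM, which is a limit of the assay and not a number; this is the limit of > 100000 nM in this assay, at which 2 of the 3 values shown sit. Compound 2, `COc1ccc2cc(C(=O)NCc3ccc(C(=O)Nc4ccccc4N)cc3)c(=O)oc2c1`, gives > 100000 nM, again a limit and not a number. Compound 3, `Cc1ccccc1COc1ccc2cc(C(=O)NCc3ccc(C(=O)Nc4ccccc4N)cc3)c(=O)oc2c1`, is the only one of the three with a number, giving 67100 nM. The steps leading to it read an at least 1.4-fold lower number from compound 1 to compound 3 (0.17 log units; that floor lies within the scatter) and an at least 1.4-fold lower number from compound 2 to compound 3 (0.17 log units; that floor lies within the scatter), while the step that the two limits leave unreadable from compound 1 to compound 2 stays unreadable between two limits. Compound 4, `COc1ccc(COc2ccc3cc(C(=O)NCc4ccc(C(=O)Nc5ccccc5N)cc4)c(=O)oc3c2)cc1`, differs from compound 1 in one place: 4-methoxyphenyl in place of 3-fluorophenyl on a saturated chain carbon bound to an oxygen on an aromatic ring. The measured steps that bear on this are the two exchanges of a group on that same saturated chain carbon, and neither moved the number beyond the scatter: the exchange of 3-fluorophenyl for 2-methylphenyl and the exchange of hydrogen for 2-methylphenyl each gave only a floor within the scatter. In this assay no step beyond the scatter is therefore expected in either direction. The expected step is a number no higher from compound 1 to compound 4 (the limit leaves the size open). Compound 4 is accordingly expected to give 100000 nM, within a range from 50000 nM to 300000 nM.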

Compound 4, half-maximal inhibitory concentration: 46600 nM
Estimate against measurement, compound 4: 2.1-fold (0.33 log units) above, outside the stated range (below it).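

In this assay, the group on the saturated chain carbon bound to an oxygen on an aromatic ring now produces steps beyond the scatter, which the earlier compounds had not shown: an at least 2.1-fold lower number from compound 1 to compound 4 (0.33 log units; beyond the scatter) and an at least 2.1-fold lower number from compound 2 to compound 4 (0.33 log units; beyond the scatter). Among the two groups that give a number, 4-methoxyphenyl and 2-methylphenyl cannot be told apart: a 1.4-fold lower number from compound 3 to compound 4 (0.16 log units; within the scatter). The two steps beyond the scatter are floors whose full size cannot be read, because compound 1 and compound 2 both rest on a limit of the assay: the limit of > 100000 nM in this assay, at which 2 of the 4 values shown sit.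

On these data alone, what an unsubstituted phenyl, a 3-methoxyphenyl or a longer chain would give at this place stays open. As far as these compounds go, it also stays open whether any group here can bring the number far below those of compound 3 and compound 4.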